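Ring Size and Linker at the Amide Nitrogen

This account rests on a few compounds, and the source may have more. Where it says the series, first, only, none or still open, it means among the compounds named here.

Measured compounds:
compound 1, `CN1CCC(NC(=O)c2ccncc2Nc2cc(-c3ccc4ccn(C)c4c3)c3nccnc3c2)CC1`: 38 nM
compound 2, `CN1CC(NC(=O)c2ccncc2Nc2cc(-c3ccc4ccn(C)c4c3)c3nccnc3c2)C1`: 30 nM

In an assay for inhibition of 6-phosphofructo-2-kinase/fructose-2,6-bisphosphatase 3 (Homo sapiens), read by ADP-Glo, with a stated time of 2 h (a lower number here means a stronger inhibitor, a higher number a weaker inhibitor), compound 2 gives 30 nM, the lowest of the two numbers, with compound 1 within the scatter of it. Compound 3, `CN1CCC(CNC(=O)c2ccncc2Nc2cc(-c3ccc4ccn(C)c4c3)c3nccnc3c2)C1`, carries (1-methylpyrrolidin-3-yl)methyl in place of 1-methylazetidin-3-yl on an amide-type nitrogen. Among the compounds with values here, the only measured step that bears on this position, a 1.3-fold lower number from compound 1 to compound 2 (0.10 log units; within the scatter), shows that the size of the amine-bearing ring on the amide nitrogen barely moved the number. A change of ring size joined to a one-carbon extension is therefore expected to give a step no larger than a 1.4-fold higher number from compound 2 to compound 3 (0.15 log units; within the scatter), and compound 3 is estimated at 42 nM with a range of 15 nM to 120 nM.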

Compound 3, half-maximal inhibitory concentration: 74 nM
For compound 3 the middle estimate is 1.8-fold (0.25 log units) below the measured one; measured number inside the range.
By their numbers in this assay, from the lowest: compounds 2, 1 and 3 (each within the scatter of the next, the first and the last beyond it).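

Within the data shown here, the (1-methylpyrrolidin-3-yl)methyl group gives the first step at this position that lies beyond the scatter, with a 2.5-fold higher number from compound 2 to compound 3 (0.39 log units; beyond the scatter) on replacing 1-methylazetidin-3-yl on the amide-type nitrogen. Replacing 1-methylpiperidin-4-yl with the same group gives a 1.9-fold higher number from compound 1 to compound 3 (0.29 log units; within the scatter) and so stays within the scatter. No measurement shown explains the larger step. Ring and linker change together in compound 3, which leaves their separate contributions open. A 1-methylpyrrolidin-3-yl group directly on the amide-type nitrogen, or a (1-methylazetidin-3-yl)methyl group, would separate them.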